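The source may report more compounds than this note shows. Statements on the series, on what has been measured and on what is new or still open speak of the compounds shown alone.

Values from a functional assay on HT-29 cells (Homo sapiens) for inhibition, read by MTT assay, with a stated time of 2 days (on this read-out higher numbers stand for weaker inhibition and lower numbers for stronger inhibition), follow
compound 1 `Oc1ccc(/C=C/c2cccc(O)c2)cc1` gives 6.9 ug/mL
compound 2 `Nc1ccccc1/C=C/c1cccc(O)c1` gives 30 ug/mL
compound 3 `Nc1cccc(/C=C/c2ccc(O)cc2)c1` gives 51 ug/mL

Compound 1 has the lowest number of the three, and both others lie beyond the scatter from it. The next compound is compound 4 `COc1ccc(/C=C/c2cccc(O)c2)cc1`, and its change is methyl in place of hydrogen on an oxygen on an aromatic ring with methyl in place of hydrogen on an oxygen on an aromatic ring, or hydroxy to methoxy. Among the compounds with values here, no measured step makes this exact change. The closest evidence is a 7.4-fold higher number from compound 1 to compound 3 (0.87 log units; beyond the scatter) for amino in place of hydroxy on an aromatic carbon. A smaller rise in the same direction is therefore expected in this assay and may stay within the scatter. The estimated step is a 1.7-fold higher number from compound 1 to compound 4 (0.24 log units; within the scatter) as a working expectation. For compound 4 the estimated value is 12 ug/mL with an expected range from 4.5 ug/mL to 30 ug/mL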

Compound 4, half-maximal inhibitory concentration: 22 ug/mL
Beside the measured number, compound 4's estimate is 1.8-fold (0.26 log units) below it; measured number inside the range.
By their numbers in this assay, from the lowest: compound 1; then compounds 4, 2 and 3 (each within the scatter of the next, the first and the last beyond it).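

Replacing the hydrogen on this oxygen with methyl in this assay gives a 3.2-fold higher number from compound 1 to compound 4 (0.50 log units; beyond the scatter), so this single added carbon is enough to shift the number at this position. With the amino change, a 7.4-fold higher number from compound 1 to compound 3 (0.87 log units; beyond the scatter), both replacements of this hydroxy seen so far raise the number beyond the scatter. No evidence on the cause of the methyl step is available. Still open, on these data alone, is whether a longer chain on this oxygen, such as ethoxy in place of methoxy, follows the same direction. As far as these compounds go, a carboxylic acid in place of this hydroxy also remains open, as does the same methyl change on the other hydroxy.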